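The source may hold more compounds than are shown below. What is called first, only, known or untested is meant among the compounds shown, and "the series" means these compounds.

For the measured compounds named here, compound 2 `COc1ccc(Cn2cc(CO/N=C/c3c(-c4ccc(C)cc4)nc4ccc(Br)cn34)nn2)cc1` is the compound with the highest of the two numbers so far: in a functional assay on the whole organism (strain NMRI) with Mus musculus as the target, with a stated time of 4 h (on this read-out higher numbers stand for an effect only at larger amounts of compound and lower numbers for an effect already at smaller amounts), compound 2 gives 40 mg/kg. Going by the values given here, its only neighbour is compound 1 `Cc1ccc(-c2nc3ccc(Br)cn3c2/C=N/OCc2cn(Cc3ccc([N+](=O)[O-])cc3)nn2)cc1`, which in this assay gives 20 mg/kg; the step of a 2.0-fold higher number from compound 1 to compound 2 (0.30 log units; within the scatter) is the sole measured step, and it stays within the scatter, so the two numbers cannot be ordered.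

Compound 3 `Cc1ccc(-c2nc3ccc(Br)cn3c2/C=N/OCc2cn(Cc3ccc(C#N)cc3)nn2)cc1` is not yet measured. It differs from compound 2 as follows: cyano in place of methoxy on an aromatic carbon. Among the compounds with values here, the only step that bears on this change is the one at the same place, from compound 1 to compound 2, where a different exchange on that aromatic carbon left the number within the scatter. Within the data shown here, on this basis no shift beyond the scatter is expected in this assay, and the step of a 1.3-fold lower number from compound 2 to compound 3 (0.12 log units; within the scatter) is an estimate placed near the centre of the two known numbers. For compound 3 the value in this assay is expected at 30 mg/kg, within a range from 12 mg/kg to 80 mg/kg.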

Compound 3, minimum effective dose: 40 mg/kg
For compound 3 the middle estimate is 1.3-fold (0.12 log units) below the measured one; the range from low to high includes it.
By their numbers in this assay, from the lowest: compounds 1, 2 and 3 (each within the scatter of the next).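

Cyano in place of methoxy on this aromatic carbon gives, in this assay, no change at the digits printed from compound 2 to compound 3 (within the scatter), and cyano in place of nitro gives a 2.0-fold higher number from compound 1 to compound 3 (0.30 log units; within the scatter). For the compounds shown here, with a third group at this place, para to a large group, compounds 1, 2 and 3 all stand within the scatter of one another, so nitro, methoxy and cyano give no step here that can be read as a shift. Nothing at hand offers an explanation for this flat result.

From the compounds shown here alone, it remains open whether any group at this place, such as an amine, a carboxylic acid or a longer chain, would move the number beyond the scatter. Compounds 1, 2 and 3 differ only at this aromatic carbon, so they say nothing about changes elsewhere on the shared core.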